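From compound 1 to compound 4 in a cytotoxicity assay

The compounds below may be only part of what the source reports. "The series", "measured", "known", "first", "only" and "open" are said of these compounds alone.

Compound 1 `O=C1/C(=C\c2c(Cl)cccc2Cl)c2ccccc2N1c1c(Cl)cccc1Cl` was examined in a functional assay on MCF7 cells (Homo sapiens) for cytotoxicity, read by MTT assay, with a stated time of 72 h; on this read-out lower numbers stand for an effect already at smaller amounts and higher numbers for an effect only at larger amounts of compound. In this assay compound 1 gives only a limit, > 100 ug/mL, and not a number. Compound 2 `O=C1/C(=C\c2cc3ccccc3nc2Cl)c2ccccc2N1c1c(Cl)cccc1Cl` likewise reaches only a limit of > 100 ug/mL in this assay. Compound 3 `Cc1ccc2nc(Cl)c(/C=C3\C(=O)N(c4c(Cl)cccc4Cl)c4ccccc43)cc2c1C` also stops at a limit of > 100 ug/mL in this assay. Among the measured compounds shown here, all three results therefore sit at the same point, (the limit of > 100 ug/mL in this assay, at which 3 of the 3 values shown sit), so compound 1 cannot be placed above or below either of the others, and no step between measured compounds exists to lean on.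

Compound 4 `CN(C)c1ccc(/C=C2\C(=O)N(c3c(Cl)cccc3Cl)c3ccccc32)cc1` has not yet been measured. It differs from compound 1 by 4-(dimethylamino)phenyl in place of 2,6-dichlorophenyl on a double-bonded chain carbon bound to a double-bonded ring carbon. With every measured compound at a limit, the size and direction of this change cannot be read from the numbers. The expected step is an at least 1.4-fold lower number from compound 1 to compound 4 (0.15 log units; that floor lies within the scatter), with wide uncertainty. Compound 4 is estimated at 70 ug/mL, between 15 ug/mL and 200 ug/mL, with a real chance that it too returns only a limit.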

Compound 4, concentration for half-maximal effect: > 100 ug/mL
Compound 4: a limit, no number (the forecaster's own chance of this, stated with the estimate: 55%); middle value at least 1.4-fold (0.15 log units) away from the limit.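

In this assay, among the compounds shown here, compound 4 gives only a limit, > 100 ug/mL, and no step from compound 1 to compound 4 can be read: the limit of > 100 ug/mL in this assay, at which 4 of the 4 values shown sit. The compounds shown leave open what actual number any of them would give in this assay.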